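The compounds below may be only part of what the source reports. "The series", "measured", "known", "first", "only" and "open" are said of these compounds alone.

Two compounds in this set share a diaryl urea core joined through an ether oxygen to a pyrimidine ring. Compound 1 `C[C@@H](O)CNc1cc(Oc2ccc(NC(=O)Nc3cccc(C(F)(F)F)c3)cc2)ncn1` carries a hydroxypropylamino chain on that ring, while compound 2 `CNc1nccc(Oc2ccc(NC(=O)Nc3cccc(C(F)(F)F)c3)cc2)n1` carries a methylamino group. In an assay on isolated protein for inhibition of serine/threonine-protein kinase TNNI3K (Homo sapiens) (a lower number here means a stronger inhibitor, a higher number a weaker inhibitor), compound 2 gives 50 nM, and compound 1 gives 63 nM; the two numbers lie within the usual scatter of each other, so neither compound can be set apart from the other on these data.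

Compound 3 `O=C(Nc1ccc(Oc2cc(NCCO)ncn2)cc1)Nc1cccc(C(F)(F)F)c1` has not yet been measured. It differs from compound 2 in one place: 6-((2-hydroxyethyl)amino)pyrimidin-4-yl in place of 2-(methylamino)pyrimidin-4-yl on an oxygen on an aromatic ring. The change puts a longer chain bearing a hydroxyl group in place of the methyl, much as compound 1 does relative to compound 2. Since compound 1 gives 63 nM, the step from compound 2 to compound 3 is expected to stay within the scatter, with no clear direction, an estimated 1.2-fold higher number from compound 2 to compound 3 (0.08 log units; within the scatter). On that basis compound 3 is estimated to reach 60 nM in this assay, with a likely range from 30 nM to 130 nM.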

Compound 3, half-maximal inhibitory concentration: 32 nM
Beside the measured number, compound 3's estimate is 1.9-fold (0.27 log units) above it; the range from low to high includes it.
By their numbers in this assay, from the lowest: compounds 3, 2 and 1 (each within the scatter of the next).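

In this assay, 6-((2-hydroxyethyl)amino)pyrimidin-4-yl in place of 2-(methylamino)pyrimidin-4-yl on an oxygen on an aromatic ring gives a 1.6-fold lower number from compound 2 to compound 3 (0.19 log units; within the scatter), so this position tolerates the larger group with its hydroxyl, with no difference that can be told apart from the scatter. Hydrogen in place of methyl on the saturated chain carbon that bears the oxygen gives a 2.0-fold lower number from compound 1 to compound 3 (0.29 log units; within the scatter), so these numbers cannot resolve any effect of that methyl, and the hydroxyl-bearing chain is tolerated with or without it. No measurement on hand explains either step.

From the compounds shown here alone, the step between compound 2 and compound 3 alters both the chain and the name-given place of the amino group on the pyrimidine, so the share of each in that step remains open. Going by these compounds, it also remains open whether this position would still tolerate a longer chain, or an amine or a carboxylic acid in place of the hydroxyl, or whether such a group would produce a step beyond the scatter.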